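Inverting the lone stereocentre of compound 2

The source may report more compounds than this note shows. Statements on the series, on what has been measured and on what is new or still open speak of the compounds shown alone.

Measured so far in a functional assay on HT-29 cells (Homo sapiens) for inhibition, read by luminescence and CellTiter-Glo, with a stated time of 10 h; on this read-out lower numbers stand for an effect already at smaller amounts and higher numbers for an effect only at larger amounts of compound:
compound 1 `CN1C(=O)[C@H](NC(=O)c2n[nH]c(Cc3ccccc3)n2)COc2ncccc21`: > 10000 nM (a limit of the assay)
compound 2 `Cc1ccc2c(n1)OC[C@H](NC(=O)c1n[nH]c(Cc3ccccc3)n1)C(=O)N2C`: 363 nM

In this assay, within the data shown here, compound 2 gives 363 nM, the only actual number so far. Compound 1 gives only a limit, > 10000 nM.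

Compound 3 `Cc1ccc2c(n1)OC[C@@H](NC(=O)c1n[nH]c(Cc3ccccc3)n1)C(=O)N2C` is the next to be read. It carries the same atoms and bonds as compound 2: the two compounds have the same atoms and bonds and differ only in configuration as drawn: 1 of 1 stereo elements differ; a stereocentre at a saturated ring carbon is drawn S in compound 2 and R in compound 3. Among the measured compounds shown here, no measured pair yet shows what such an inversion does, so the expectation is a judgement. A large step toward higher numbers is expected in this assay, rather than none beyond the scatter, and a reading that reports only a limit is quite possible. The expected change is a 22-fold higher number from compound 2 to compound 3 (1.34 log units; beyond the scatter). For compound 3 the estimated value is 8000 nM, with an expected range from 2000 nM to 30000 nM.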

Compound 3, half-maximal effective concentration: 6500 nM
The estimate for compound 3 lay 1.2-fold (0.09 log units) above the measured number; low and high end bracket the measured number.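

In this assay the inversion gives an 18-fold higher number from compound 2 to compound 3 (1.25 log units; beyond the scatter), the first sign that configuration at this saturated ring carbon matters, with the S form as drawn in compound 2 giving the lower number. The step can be assigned to this stereocentre alone because nothing else changes: the fact that compounds 2 and 3 differ only in the configuration as drawn. Methyl in place of hydrogen on an aromatic carbon gives an at least 1.5-fold lower number from compound 1 to compound 3 (0.18 log units; that floor lies within the scatter), and this remains only a floor because compound 1 gives a limit of the assay: the limit of > 10000 nM in this assay, at which 1 of the 3 values shown sits.

How much the methyl contributes to the 363 nM of compound 2 remains open, as the compounds shown include no S form that carries hydrogen on that aromatic carbon. Also open, on these data alone, is whether an ethyl, a methoxy or an amine in place of that methyl would keep the number of compound 2.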